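The compounds below may be only part of what the source reports. "The series", "measured", "known", "first", "only" and "open" are said of these compounds alone.

Of the compounds shown here, three that share one core have been measured. Compound 1 `Nc1scc(CN2CCN(c3ccc(Cl)cc3Cl)CC2)c1C(=O)c1ccc(Cl)cc1` bears a 2,4-dichlorophenyl on an amine nitrogen in a ring, and in a functional assay on CHO cells with adenosine receptor A1 (Homo sapiens) as the target, read by cAMP accumulation and immunoassay, with a stated time of 6 min, tested at 0.1 uM (a higher number here means a weaker effect of the compound at the concentration tested, a lower number a stronger effect), compound 1 gives -11%. Compound 2 `Nc1scc(CN2CCN(c3cc(F)cc(F)c3)CC2)c1C(=O)c1ccc(Cl)cc1` bears a 3,5-difluorophenyl on that nitrogen, and in this assay compound 2 gives -5%. Compound 3 `Nc1scc(CN2CCN(c3cc(F)ccc3F)CC2)c1C(=O)c1ccc(Cl)cc1` bears a 2,5-difluorophenyl, and in this assay compound 3 gives -13%. The three numbers all sit within the usual scatter of one another: the steps are a number 6 percentage points higher from compound 1 to compound 2 (within the scatter), a number 2 percentage points lower from compound 1 to compound 3 (within the scatter) and a number 8 percentage points lower from compound 2 to compound 3 (within the scatter). On these numbers compound 3 cannot be told apart from either of the other two.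

Compound 4 `Nc1scc(CN2CCN(c3ccc(F)c(Cl)c3)CC2)c1C(=O)c1ccc(Cl)cc1` has not yet been measured. Relative to compound 3 the change is 3-chloro-4-fluorophenyl in place of 2,5-difluorophenyl on an amine nitrogen in a ring. Each of the three measured steps likewise exchanges one substituted phenyl for another on the same nitrogen, and none of them shifted the number beyond the scatter. The same outcome is expected here: in this assay the expected step is a number 3 percentage points higher from compound 3 to compound 4 (within the scatter), nothing beyond the scatter. Compound 4 is thus expected to give about -10%, within a range from -25% to 8%.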

Compound 4, a percentage reported as activity, at one concentration (the size of the read-out at that concentration, not a potency): -21%
For compound 4 the middle estimate is 11 percentage points above the measured one, within the range that was stated.
By their numbers in this assay, from the lowest: compounds 4, 3, 1 and 2 (each within the scatter of the next, the first and the last beyond it).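

For the compounds shown here, replacing 3,5-difluorophenyl with 3-chloro-4-fluorophenyl on the amine nitrogen gives the first step at this position that leaves the scatter in this assay: a number 16 percentage points lower from compound 2 to compound 4 (beyond the scatter). The other two new steps stay inside it, a number 8 percentage points lower from compound 3 to compound 4 (within the scatter) and a number 10 percentage points lower from compound 1 to compound 4 (within the scatter), so this position does respond to the exchange of one substituted phenyl for another, but so far only modestly and in this one pair. No measurement is available that would explain this step.

From the compounds shown here alone, all four phenyl groups carry only chlorine or fluorine, so the effect of a methoxy group, an amine or a carboxylic acid on that ring remains open. Each number also comes from a single concentration, so the potency of these compounds remains open too.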